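A few compounds are considered here, and "the series" means these few. Any claim that something is new, unique, unknown or untested is made for them only; others in the source may bear on it.

In a physicochemical assay for solubility, at pH 6.8 (on this read-out higher numbers stand for higher solubility and lower numbers for lower solubility), the three measured compounds all land at a limit of the assay rather than at a number. Compound 1 `Cc1c(COCCCCO)[nH]c2ccccc2c1=O` gives >= 100000 nM, a limit. Compound 2 `Cc1c(COc2cccc(OCC3CCOCC3)c2)[nH]c2ccc(-c3cccnc3)cc2c1=O` gives < 1000 nM, also a limit. Compound 3 `Cc1c(COc2cccc(OCC3CCOCC3)c2)[nH]c2ccc(Cl)cc2c1=O` likewise gives < 1000 nM, a limit, so its solubility is known only as a bound. For the measured compounds named here, the single measured step, a step that the two limits leave unreadable from compound 2 to compound 3, runs between two limits and its size cannot be read. What the set offers is thin: the limit of < 1000 nM in this assay, at which 2 of the 3 values shown sit, and (the limit of >= 100000 nM in this assay, at which 1 of the 3 values shown sits).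

Compound 4 `COc1ccc2[nH]c(COc3cccc(OCC4CCOCC4)c3)c(C)c(=O)c2c1` differs from compound 3 in one place: methoxy in place of chloro on an aromatic carbon. Going by the values given here, no measured step bears on this change, and the values of compound 2 and compound 3 show only that both sit at the same limit. The expectation is therefore that compound 4 stays close to where compound 3 stands, with an estimated step that the limit leaves unreadable from compound 3 to compound 4 that is not expected to exceed the scatter. The estimate for compound 4 is 800 nM, within a range from 200 nM to 3000 nM, with a fair chance that the assay again returns only a limit.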

Compound 4, solubility: < 1000 nM
Compound 4: no number, only a limit; the forecaster's own chance of this, stated with the estimate: 60%; the middle value is on the limit's open side.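

In this assay, compound 4 sits at the same limit as compound 2 and compound 3, so no step among these three compounds can be read. The compounds shown leave open where the actual solubility of each lies, and whether pyridin-3-yl, chloro and methoxy differ at all.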